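Methyl on the phenol oxygen of compound 3

The compounds below may be only part of what the source reports. "The series", "measured", "known", "first", "only" and "open" are said of these compounds alone.

Values so far in a functional assay on HeLa cells (Homo sapiens) for cytotoxicity, read by WST assay, with a stated time of 48 h; a lower number here means a stronger inhibitor, a higher number a weaker inhibitor (compound, structure, value):
compound 1 `COc1ccc(/C=C/C[C@@H]2C[C@@H]([C@@H](O)c3ccc(OC)c(OC)c3)CO[C@H]2c2ccc(OC)c(OC)c2)cc1` gives 17100 nM 
compound 2 `Oc1ccccc1/C=C/C[C@H]1C[C@@H]([C@@H](O)c2ccccc2)CO[C@@H]1c1ccccc1` gives 21800 nM 
compound 3 `Oc1ccc(/C=C/C[C@H]2C[C@@H]([C@@H](O)c3ccccc3)CO[C@@H]2c2ccccc2)cc1` gives 14400 nM 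

Compound 3 sits within the scatter of both compound 1 and compound 2. Compound 4 (`COc1ccc(/C=C/C[C@H]2C[C@@H]([C@@H](O)c3ccccc3)CO[C@@H]2c2ccccc2)cc1`) has methyl in place of hydrogen on an oxygen on an aromatic ring, turning 4-hydroxyphenyl into 4-methoxyphenyl. Within the data shown here, no measured step shows this exchange directly. Among the measured compounds shown here, the one step touching that ring (a 1.5-fold lower number from compound 2 to compound 3 (0.18 log units; within the scatter)) stays within the scatter, so the series gives no sign of sensitivity there. Expected in this assay is a 1.0-fold higher number from compound 3 to compound 4 (0.02 log units; within the scatter) and thus no step beyond the scatter. For compound 4 the estimated value is 15000 nM with an expected range from 8000 nM to 28000 nM in this read-out.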

Compound 4, half-maximal inhibitory concentration: 8300 nM
Compound 4: middle estimate off by 1.8-fold (0.26 log units), on the high side, within the range that was stated.
By their numbers in this assay, from the lowest: compounds 4, 3, 1 and 2 (each within the scatter of the next, the first and the last beyond it).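

In this assay, methyl can replace the hydrogen on the oxygen of the 4-hydroxyphenyl group without a step beyond the scatter (a 1.7-fold lower number from compound 3 to compound 4 (0.24 log units; within the scatter)). Among these compounds, the change from 2-hydroxyphenyl to 4-methoxyphenyl gives the first step beyond the scatter, though a modest one (a 2.6-fold lower number from compound 2 to compound 4 (0.42 log units; beyond the scatter)). No measurement at hand accounts for either step.

Open, as far as these compounds go, is whether an ethyl group on that oxygen, or an amine in place of the hydroxy, would stay within the scatter of compound 3.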